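A few compounds are considered here, and "the series" means these few. Any claim that something is new, unique, unknown or untested is made for them only; others in the source may bear on it.

Three compounds sharing one core have been tested in a functional assay on A549 cells (Homo sapiens) for cytotoxicity, read by MTT assay, with a stated time of 72 h; on this read-out lower numbers stand for stronger inhibition and higher numbers for weaker inhibition:

compound 1 `COc1ccc(/C=N/NC(=O)Nc2ccc(Oc3ccnc(-c4nncn4CCN(C)C)c3)c(F)c2)c(OC)c1OC`: 6680 nM
compound 2 `CN(C)CCn1cnnc1-c1cc(Oc2ccc(NC(=O)N/N=C/c3ccccc3O[N+](=O)[O-])cc2F)ccn1`: 1200 nM
compound 3 `CN(C)CCn1cnnc1-c1cc(Oc2ccc(NC(=O)N/N=C/c3ccc(Cl)cc3)cc2F)ccn1`: 780 nM

Compound 3 carries the lowest number of the three. Its gap to compound 2 is small, a 1.5-fold lower number from compound 2 to compound 3 (0.19 log units; within the scatter), so the two cannot be ranked against each other. Its gap to compound 1 is larger, an 8.6-fold lower number from compound 1 to compound 3 (0.93 log units; beyond the scatter), and that one does stand out from the scatter.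

Compound 4 `CN(C)CCn1cnnc1-c1cc(Oc2ccc(NC(=O)N/N=C/c3cccc(O)c3)cc2F)ccn1` is the next variation on the same ring: 3-hydroxyphenyl in place of 4-chlorophenyl on a carbon with a double bond to nitrogen. Every measured step here is an exchange of this same ring, so all three bear on it. Replacing the 2,3,4-trimethoxyphenyl ring by 2-(nitrooxy)phenyl gave a 5.6-fold lower number from compound 1 to compound 2 (0.75 log units; beyond the scatter), replacing it by 4-chlorophenyl gave an 8.6-fold lower number from compound 1 to compound 3 (0.93 log units; beyond the scatter), and moving between the two singly substituted rings gave a 1.5-fold lower number from compound 2 to compound 3 (0.19 log units; within the scatter). The ring with three substituents gave the highest number; the two rings with one substituent each sat close together. Among the measured compounds shown here, no measured step puts a hydroxyl group on this ring, so the expectation rests on that loose picture alone.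

The expected step for compound 4 is a modest rise, a 1.9-fold higher number from compound 3 to compound 4 (0.28 log units; within the scatter), possibly not beyond the scatter. Compound 4 is therefore estimated at 1500 nM, with a range of 500 nM to 4500 nM.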

Compound 4, half-maximal inhibitory concentration: > 100000 nM
Compound 4 was reported as a limit; the forecaster's own chance of this, stated with the estimate: 5%; at least 66-fold (1.82 log units) between middle value and limit.
By their numbers in this assay, from the lowest: compounds 3 and 2 (each within the scatter of the next); then compound 1. At a limit, above all of these: compound 4.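

In this assay compound 4 is reported only as a limit, not as a number: the limit of > 100000 nM in this assay, at which 1 of the 4 values shown sits. Even so, the steps can be read in one direction, as an at least 120-fold higher number from compound 3 to compound 4 (2.10 log units; beyond the scatter), an at least 83-fold higher number from compound 2 to compound 4 (1.92 log units; beyond the scatter) and an at least 14-fold higher number from compound 1 to compound 4 (1.17 log units; beyond the scatter), and each is large and beyond the scatter. The earlier exchanges on this ring moved the number only modestly, whereas this one shows that the position is far from indifferent to what it carries: 3-hydroxyphenyl has the same number of heavy atoms as 4-chlorophenyl and adds a hydrogen-bond donor and acceptor, yet compound 4 ends up beyond every other compound shown, including the one with the trimethoxyphenyl ring.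

The compounds shown cannot say whether this drop follows the hydroxyl group itself or its place on the ring, since this exchange changes both the group and where it sits. On these data alone, a 4-hydroxyphenyl ring would test the place of the hydroxyl group, and a 3-chlorophenyl or 3-methoxyphenyl ring would test whether any group at that spot behaves like the hydroxyl group, but how such rings would fare remains open.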